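Hydroxy Addition on the Fluorophenyl Chalcone Pair

The source may report more compounds than this note shows. Statements on the series, on what has been measured and on what is new or still open speak of the compounds shown alone.

Compound 1 `COc1ccc(/C=C/C(=O)c2ccccc2-c2ccc(F)cc2)cc1` is the reference; in a functional assay on A549 cells (Homo sapiens) for antiproliferative activity, read by sulforhodamine B assay, with a stated time of 48 h (a lower number here means a stronger inhibitor, a higher number a weaker inhibitor), compound 1 gives 210 nM. Compound 2 `COc1ccc(/C=C/C(=O)c2ccccc2-c2ccc(F)cc2)cc1O` carries the change hydroxy in place of hydrogen on an aromatic carbon and in this assay compound 2 gives 430 nM, a step of a 2.0-fold higher number from compound 1 to compound 2 (0.31 log units; beyond the scatter). Compound 3 `COc1ccc(/C=C/C(=O)c2ccccc2-c2cccc(F)c2)cc1` differs from compound 1 by 3-fluorophenyl in place of 4-fluorophenyl on an aromatic carbon; in this assay compound 3 gives 480 nM, a step of a 2.3-fold higher number from compound 1 to compound 3 (0.36 log units; beyond the scatter). Compound 2 and compound 3 lie within the scatter of each other.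

Compound 4 `COc1ccc(/C=C/C(=O)c2ccccc2-c2cccc(F)c2)cc1O` is not yet measured. It differs from compound 3 by hydroxy in place of hydrogen on an aromatic carbon, the same change as that from compound 1 to compound 2, on a core that differs by 3-fluorophenyl in place of 4-fluorophenyl on an aromatic carbon. For the measured compounds named here, the only measured instance of this change, from compound 1 to compound 2, is a 2.0-fold higher number from compound 1 to compound 2 (0.31 log units; beyond the scatter), and with a single precedent the transfer to the core of compound 3 is uncertain. The expected step for compound 4 is therefore a 2.0-fold higher number from compound 3 to compound 4 (0.30 log units; within the scatter), resting on the step from compound 1 to compound 2 a 2.0-fold higher number from compound 1 to compound 2 (0.31 log units; beyond the scatter) applied to compound 3 at 480 nM. For compound 4 the estimate in this assay is 950 nM, expected between 480 nM and 1900 nM.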

Compound 4, half-maximal inhibitory concentration: 180 nM
Estimate against measurement, compound 4: 5.3-fold (0.72 log units) above, outside the stated range (below it).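

Hydroxy in place of hydrogen does not carry over between these two cores in this assay: with 3-fluorophenyl in place of 4-fluorophenyl already present the step is a 2.7-fold lower number from compound 3 to compound 4 (0.43 log units; beyond the scatter) and runs opposite to the earlier one: the same change on two cores in this assay, a 2.0-fold higher number (0.31 log units; beyond the scatter) from compound 1 to compound 2 and a 2.7-fold lower number (0.43 log units; beyond the scatter) from compound 3 to compound 4, 5.5-fold (0.74 log units) apart, beyond the scatter of two such steps. Read the other way round, 3-fluorophenyl in place of 4-fluorophenyl also depends on the core, with a 2.4-fold lower number from compound 2 to compound 4 (0.38 log units; beyond the scatter) when the hydroxy is present, again opposite to the step without it: the same change on two cores in this assay, a 2.3-fold higher number (0.36 log units; beyond the scatter) from compound 1 to compound 3 and a 2.4-fold lower number (0.38 log units; beyond the scatter) from compound 2 to compound 4, 5.5-fold (0.74 log units) apart, beyond the scatter of two such steps. Across these four compounds the two changes therefore do not add up, and a step measured on one core is no safe guide on the other, but a single pair of cores gives no reason for the reversal and does not show how either change would run on any further core.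

Open, on these data alone, is whether the reversal would hold with an amine or a second methoxy group in place of the hydroxy, ortho to the methoxy group. Also open, as far as these compounds go, is the outcome with chlorine in place of the fluorine on the phenyl group.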